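Fluoro to methoxy: expected maximal response of compound 3

A few compounds are considered here, and "the series" means these few. Any claim that something is new, unique, unknown or untested is made for them only; others in the source may bear on it.

Measured so far:
Compound 1 `CSc1ccc(C)cc1NCC1=NCCN1`: 96%
Compound 2 `CSc1ccc(F)cc1NCC1=NCCN1`: 92%

In a functional assay for agonist activity at Alpha-1B adrenergic receptor (Homo sapiens) (a lower number here means a smaller maximal response, a higher number a larger maximal response), compound 1 gives 96% and compound 2 gives 92%. Within the data shown here, both numbers lie close to the reference, and the only measured step, a number 4 percentage points lower from compound 1 to compound 2 (within the scatter), stays within the scatter, so compound 2 cannot be told apart from compound 1 on these two numbers.

Compound 3 `COc1ccc(SC)c(NCC2=NCCN2)c1` is not yet measured. It differs from compound 2 in one place: methoxy in place of fluoro on an aromatic carbon. Among the measured compounds shown here, the one step that bears on this change is the exchange at the same aromatic carbon, a number 4 percentage points lower from compound 1 to compound 2 (within the scatter), where a fluoro replacing a methyl left the maximal response essentially unchanged. Nothing measured here points to a group at that carbon moving the response beyond the scatter, so no step beyond the scatter is expected for a methoxy entering in place of the fluoro.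

Compound 3 is therefore estimated to give 92%, with a range from 78% to 102%. The expected step, no change at the digits printed from compound 2 to compound 3 (within the scatter), is within the scatter.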

Compound 3, largest response reached (reported as maximum), in percent of the reference or control that the assay uses: 92%
Estimate against measurement, compound 3: no gap at the digits printed; measured number inside the range.
By their numbers in this assay, from the lowest: compounds 2, 3 and 1 (each within the scatter of the next).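

In this assay, the aromatic carbon para to the methylsulfanyl group now carries a third group, and the maximal response still cannot be told apart across the series. Methoxy in place of fluoro gives no change at the digits printed from compound 2 to compound 3 (within the scatter), and methoxy in place of methyl gives a number 4 percentage points lower from compound 1 to compound 3 (within the scatter), so this result extends the earlier comparison of methyl and fluoro to a group with 2 heavy atoms and 1 hydrogen-bond acceptor, where fluoro is counted with 1 heavy atom and no acceptor. No supporting data are available to explain why these exchanges leave the numbers within the scatter.

The compounds shown do not reveal whether a carboxylic acid, an amine or a longer chain such as butoxy at this same carbon would give a response that differs beyond the scatter. The methylsulfanyl group is also the same in all three compounds, so its replacement by a group such as ethyl leaves open how much of the maximal response depends on it.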